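The compounds below may be only part of what the source reports. "The series", "measured", "known", "first", "only" and "open" are said of these compounds alone.

Working notes on the series

The shared core carries a trifluoromethylphenyl group and a two-carbon double-bonded chain ending in a saturated ring. Compound 1 `FC1(F)CCC(/C=C/c2nc3cc(-c4ccccc4C(F)(F)F)ccc3[nH]2)CC1` bears a 4,4-difluorocyclohexyl group on that chain; in a functional assay on HEK293 cells for antagonist activity at transient receptor potential M8 protein (Canis lupus familiaris), read by FLIPR and calcium flux (a higher number here means a weaker inhibitor, a lower number a stronger inhibitor), compound 1 gives 21 nM. Compound 2 `CC1(/C=C/c2nc3cc(-c4ccccc4C(F)(F)F)ccc3[nH]2)CCC(F)(F)CC1` adds a methyl to that ring, and in this assay compound 2 gives 8.9 nM, a step of a 2.4-fold lower number from compound 1 to compound 2 (0.37 log units; beyond the scatter). Compound 3 `FC(F)(F)c1ccccc1-c1ccc2[nH]c(/C=C/C3CCOCC3)nc2c1` carries an oxan-4-yl group instead; in this assay compound 3 gives 7.1 nM, which is the lowest of the three numbers, with a 3.0-fold lower number from compound 1 to compound 3 (0.47 log units; beyond the scatter) but only a 1.3-fold lower number from compound 2 to compound 3 (0.10 log units; within the scatter), so compound 3 and compound 2 cannot be ordered.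

Compound 4 `FC(F)(F)c1ccccc1-c1ccc2[nH]c(/C=C/C3CCSCC3)nc2c1` differs from compound 3 by thian-4-yl in place of oxan-4-yl on a double-bonded chain carbon bound to a double-bonded chain carbon. Among the compounds with values here, no measured step tests an oxygen-to-sulfur swap within the saturated ring; the steps that replace the whole ring, from compound 1 or compound 2 to compound 3, were modest or within the scatter. An exchange of one ring heteroatom for another of the same count is therefore expected to move this assay little, with a step of a 1.3-fold higher number from compound 3 to compound 4 (0.10 log units; within the scatter) estimated for compound 4, in no clear direction. Compound 4 is expected to give about 9 nM, within 3 nM to 27 nM.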

Compound 4, half-maximal inhibitory concentration: 31 nM
Compound 4: middle estimate off by 3.4-fold (0.54 log units), on the low side; measured number outside the range, above it.
By their numbers in this assay, from the lowest: compounds 3 and 2 (each within the scatter of the next); then compounds 1 and 4 (each within the scatter of the next).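

Working notes, continued

Within this assay, the exchange of ring oxygen for ring sulfur on a double-bonded chain carbon bound to a double-bonded chain carbon is not a silent one, since thian-4-yl in place of oxan-4-yl gives a 4.4-fold higher number from compound 3 to compound 4 (0.64 log units; beyond the scatter) even though the heavy-atom, hetero-atom and hydrogen-bond acceptor counts stay the same. The comparison with the other ring groups places thian-4-yl apart from 4,4-difluoro-1-methylcyclohexyl, with a 3.5-fold higher number from compound 2 to compound 4 (0.54 log units; beyond the scatter) in that step, but not apart from 4,4-difluorocyclohexyl, with a 1.5-fold higher number from compound 1 to compound 4 (0.17 log units; within the scatter) in that step, so those last two groups cannot be ordered at this place. Nothing in the available data accounts for the difference between the oxan-4-yl and thian-4-yl compounds.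

The compounds shown leave open whether a ring amine, as in piperidin-4-yl, or the oxidised sulfur of 1,1-dioxothian-4-yl would track with oxan-4-yl or with thian-4-yl at this place. Within the data shown here, they also leave open whether methyl in place of hydrogen on a saturated ring carbon, so far seen only on the 4,4-difluorocyclohexyl group, would give a comparable step on oxan-4-yl or thian-4-yl.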